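Indole nitrogen: methyl versus hydrogen in the series

The compounds below may be only part of what the source reports. "The series", "measured", "known", "first", "only" and "open" are said of these compounds alone.

Two compounds carry the imidazolylmethyl arm and the carboxylic acid on their shared core. In an assay for inhibition of Thromboxane-A synthase (Homo sapiens) (on this read-out lower numbers stand for stronger inhibition and higher numbers for weaker inhibition), compound 1 `Cc1c(Cn2ccnc2)sc2cc(C(=O)O)ccc12` gives 18 nM. Compound 2 `Cc1c(Cn2ccnc2)n(C)c2ccc(C(=O)O)cc12`, the indole analogue, gives 32 nM in this assay, and the two values lie within the usual scatter of each other, so neither compound can be called the more potent. Compound 3 `Cc1c(Cn2ccnc2)[nH]c2ccc(C(=O)O)cc12` differs from compound 2 by hydrogen in place of methyl on an aromatic nitrogen. For the measured compounds named here, no measured pair shows this step, so the expected step of a 1.1-fold lower number from compound 2 to compound 3 (0.03 log units; within the scatter) is small, with no clear direction beyond the scatter. Compound 3 is estimated at 30 nM in this assay, with a range from 10 nM to 90 nM.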

Compound 3, half-maximal inhibitory concentration: 37 nM
Beside the measured number, compound 3's estimate is 1.2-fold (0.09 log units) below it, and the stated range covers the measured number.
By their numbers in this assay, from the lowest: compounds 1, 2 and 3 (each within the scatter of the next, the first and the last beyond it).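

In this assay, for the compounds shown here, replacing methyl with hydrogen on the aromatic nitrogen gives a 1.2-fold higher number from compound 2 to compound 3 (0.06 log units; within the scatter), the first measured reading of this step. On this core, the methyl group on this nitrogen is not required to keep the number at this level, and hydrogen there cannot be told apart from it. No available evidence bears on this result. Still open, on these data alone, is whether a longer chain such as propyl, or an amine-bearing chain, on this nitrogen would leave the number within the scatter.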